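Dropping the Benzylic Methyl: From Compound 2 to Compound 3

A few compounds are considered here, and "the series" means these few. Any claim that something is new, unique, unknown or untested is made for them only; others in the source may bear on it.

compound 1 `C[C@@H](NC1CCN(CCCc2c[nH]c3ccc(-n4ccnc4)cc23)CC1)c1ccccc1`: 110 nM
compound 2 `CC(=O)Nc1ccc([C@@H](C)NCC2CCN(CCCc3c[nH]c4ccc(-n5cnnc5)cc34)CC2)cc1`: 8.9 nM

In an assay on CHO cells for displacement of a labelled ligand from 5-hydroxytryptamine receptor 1B (Homo sapiens) (a lower number here means a stronger inhibitor, a higher number a weaker inhibitor), compound 2 gives 8.9 nM, the lowest of the two numbers shown; compound 1, with 110 nM, sits well above it, a gap beyond the usual scatter. Going by the values given here, no pair of measured compounds differs in a single place, so no measured step guides the next move. Compound 3 `CC(=O)Nc1ccc(CNCC2CCN(CCCc3c[nH]c4ccc(-n5cnnc5)cc34)CC2)cc1` differs from compound 2 by hydrogen in place of methyl on a saturated chain carbon bound to an amine nitrogen and an aromatic carbon. A modest weakening is expected, with the step of a 2.5-fold higher number from compound 2 to compound 3 (0.39 log units; beyond the scatter) near the edge of the scatter. Compound 3 is therefore estimated at 22 nM, with a range from 7 nM to 65 nM.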

Compound 3, half-maximal inhibitory concentration: 8.9 nM
Compound 3: middle estimate off by 2.5-fold (0.39 log units), on the high side; measured number inside the range.
By their numbers in this assay, from the lowest: compounds 2 and 3 (each within the scatter of the next); then compound 1.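

In this assay, hydrogen in place of methyl on the saturated chain carbon bound to an amine nitrogen and an aromatic carbon gives no change at the digits printed from compound 2 to compound 3 (within the scatter), so the 4-acetamidobenzyl group holds the number set by the 1-(4-acetamidophenyl)ethyl group. At this position, in this compound, the methyl is not needed to keep that number. Nothing available accounts for this result. Still open, as far as these compounds go, is whether an ethyl or a hydroxymethyl on this carbon would keep the number, and whether the same change would read alike on the core of compound 1.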